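Methylating the ring amine of a kinase inhibitor

The source may report more compounds than this note shows. Statements on the series, on what has been measured and on what is new or still open speak of the compounds shown alone.

Three measured compounds share one core and differ only in the ring attached through oxygen. Compound 1 `Cc1n[nH]c2nc(-c3ccc(NS(=O)(=O)c4cc(Cl)ccc4F)cc3)nc(OC3CCOCC3)c12` gives 5 nM in an assay for inhibition of serine/threonine-protein kinase Sgk1 (Homo sapiens), with stated times of 30 min and 60 min, in the presence of a further agent that is not named here; a higher number here means a weaker inhibitor, a lower number a stronger inhibitor; compound 2 `Cc1n[nH]c2nc(-c3ccc(NS(=O)(=O)c4cc(Cl)ccc4F)cc3)nc(OC3CCC(=O)CC3)c12` gives 5 nM; compound 3 `Cc1n[nH]c2nc(-c3ccc(NS(=O)(=O)c4cc(Cl)ccc4F)cc3)nc(OC3CC(C)(C)NC(C)(C)C3)c12` gives 3 nM, the lowest of the three numbers, though its gaps to both neighbours lie within the scatter. The steps of no change at the digits printed from compound 1 to compound 2 (within the scatter), a 1.7-fold lower number from compound 1 to compound 3 (0.22 log units; within the scatter) and a 1.7-fold lower number from compound 2 to compound 3 (0.22 log units; within the scatter) all exchange the whole ring on the oxygen, and none moves the number beyond the scatter. Compound 4 `Cc1n[nH]c2nc(-c3ccc(NS(=O)(=O)c4cc(Cl)ccc4F)cc3)nc(OC3CC(C)(C)N(C)C(C)(C)C3)c12` is the unmeasured compound, differing from compound 3 by methyl in place of hydrogen on an amine nitrogen in a ring. Within the data shown here, no measured step probes this smaller change, so compound 4 is expected to show no change at the digits printed from compound 3 to compound 4 (within the scatter), with an estimated value of 3 nM within 1.5 nM to 7 nM.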

Compound 4, half-maximal inhibitory concentration: 2 nM
Estimate against measurement, compound 4: 1.5-fold (0.18 log units) above; measured number inside the range.
By their numbers in this assay, from the lowest: compounds 4, 3, 1 and 2 (each within the scatter of the next, the first and the last beyond it).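

In this assay, the amine nitrogen in the ring can carry methyl in place of hydrogen while the number stays within the scatter (a 1.5-fold lower number from compound 3 to compound 4 (0.18 log units; within the scatter)). Among these compounds, with this methyl present, the exchange of the whole ring on the oxygen passes the scatter for the first time, though only modestly (a 2.5-fold lower number from compound 1 to compound 4 (0.40 log units; beyond the scatter)) and (a 2.5-fold lower number from compound 2 to compound 4 (0.40 log units; beyond the scatter)). No measurement offered here explains these steps.

Going by these compounds, what an ethyl group, an acetyl group or a longer chain on this nitrogen would do remains open. So does the part played by the four methyl groups on the ring.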